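A few compounds are considered here, and "the series" means these few. Any claim that something is new, unique, unknown or untested is made for them only; others in the source may bear on it.

Compound 2, `COc1ccc(C(=O)/C=C/c2ccc(OCc3cn(Cc4cccc(Br)c4)nn3)cc2)cc1`, is one of two compounds with a number in a functional assay on A549 cells (Homo sapiens) for inhibition, read by MTT assay, with a stated time of 48 h, tested at 10 uM; a higher number here means more inhibition of growth at the concentration tested, a lower number less inhibition of growth: compound 2 gives 47%. The other is compound 1, `COc1ccc(C(=O)/C=C/c2ccc(OCc3cn(Cc4ccccc4)nn3)cc2)cc1`, which in this assay gives 44%; the two numbers lie within the scatter of each other, as the step of a number 3 percentage points higher from compound 1 to compound 2 (within the scatter) shows. Compound 3, `COc1ccc(C(=O)/C=C/c2ccc(OCc3cn(Cc4ccc(Br)cc4)nn3)cc2)cc1`, differs from compound 2 by 4-bromophenyl in place of 3-bromophenyl on a saturated chain carbon bound to an aromatic nitrogen. Going by the values given here, no measured step moves a bromine from one place on this ring to another, so nothing bears directly on the change. Among the compounds with values here, the one step available, a number 3 percentage points higher from compound 1 to compound 2 (within the scatter), shows that putting bromine onto this ring at all left the number within the scatter, which gives no reason to expect the shift of the bromine to matter more. Compound 3 is therefore expected to show no change at the digits printed from compound 2 to compound 3 (within the scatter), no step beyond the scatter. The estimate for compound 3 in this assay is 47%, with a range from 35% to 59%.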

Compound 3, percent growth inhibition at one concentration: 50%
For compound 3 the middle estimate is 3 percentage points below the measured one; the range from low to high includes it.
By their numbers in this assay, from the lowest: compounds 1, 2 and 3 (each within the scatter of the next).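

Going by these compounds alone, changing 3-bromophenyl to 4-bromophenyl on a saturated chain carbon bound to an aromatic nitrogen gives in this assay a number 3 percentage points higher from compound 2 to compound 3 (within the scatter) and thus supplies the direct test of the bromine's place that the earlier compounds lacked. Within these two compounds, the place of the bromine on this ring makes no difference that can be read. The comparison with the unbrominated compound agrees, with a number 6 percentage points higher from compound 1 to compound 3 (within the scatter) as a step that also leaves the bromine's presence unresolved, and no supporting measurement is available to explain these numbers.

On these data alone, whether an amine or a carboxylic acid on this ring, or a longer chain in place of the saturated chain carbon, would move the number beyond the scatter remains open. Also open, as far as these compounds go, is whether these compounds would separate in other cells or at other concentrations.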